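Compound 3: a new substituent on the same core

The source may hold more compounds than are shown below. What is called first, only, known or untested is meant among the compounds shown, and "the series" means these compounds.

compound 1 `O=C(/C=C/c1ccc(O)c(O)c1)N1CCN(c2ccc(F)cc2)CC1` gives 1.68 ug/mL
compound 2 `O=C(/C=C/c1ccc(O)c(O)c1)N1CCN(c2ccc([N+](=O)[O-])cc2)CC1` gives 1.79 ug/mL

In a functional assay on B16-F10 cells (Mus musculus) for antiproliferative activity, read by MTT assay, with a stated time of 48 h (on this read-out higher numbers stand for weaker inhibition and lower numbers for stronger inhibition), compound 2 gives 1.79 ug/mL, level with compound 1 within the scatter. Compound 3 `Cc1ccc(N2CCN(C(=O)/C=C/c3ccc(O)c(O)c3)CC2)c(C)c1` differs from compound 2 as follows: 2,4-dimethylphenyl in place of 4-nitrophenyl on an amine nitrogen in a ring. For the measured compounds named here, one measured step bears on this change, nitro in place of fluoro on an aromatic carbon: a 1.1-fold higher number from compound 1 to compound 2 (0.03 log units; within the scatter). That single step stays within the scatter, so no shift beyond the scatter is expected in this assay, in either direction. The expected change is a 1.1-fold higher number from compound 2 to compound 3 (0.05 log units; within the scatter). For compound 3 the estimated value is 2 ug/mL, with an expected range from 0.9 ug/mL to 4.5 ug/mL.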

Compound 3, half-maximal inhibitory concentration: 1.43 ug/mL
Estimate against measurement, compound 3: 1.4-fold (0.15 log units) above, and the stated range covers the measured number.
By their numbers in this assay, from the lowest: compounds 3, 1 and 2 (each within the scatter of the next).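

Replacing the aryl group on the ring amine nitrogen with 2,4-dimethylphenyl, which has no hydrogen-bond acceptors, leaves the read-out in this assay essentially unchanged: a 1.3-fold lower number from compound 2 to compound 3 (0.10 log units; within the scatter) and a 1.2-fold lower number from compound 1 to compound 3 (0.07 log units; within the scatter). Both steps stay within the scatter, so 4-fluorophenyl, 4-nitrophenyl and 2,4-dimethylphenyl sit level at this position. Nothing available explains this result. Still open, going by these compounds, is whether an aromatic ring is needed here at all, and whether a benzyl group or a phenyl ring bearing a carboxylic acid would hold the same level.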